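A few compounds are considered here, and "the series" means these few. Any claim that something is new, unique, unknown or untested is made for them only; others in the source may bear on it.

Compound 1 `Cc1nc(-c2ccc(F)cc2)c(C(=O)N2CCN(c3cccc(Cl)c3)CC2)o1` is one of three compounds examined in a functional assay on HL-60 cells (Homo sapiens) for inhibition, read by MTT assay, with a stated time of 72 h; a higher number here means a weaker inhibitor, a lower number a stronger inhibitor. Compound 1 gives 40.1 nM in this assay, the lowest of the two numbers reported. Compound 2 `Cc1nc(-c2ccccc2Cl)c(C(=O)N2CCN(c3cccc(Cl)c3)CC2)o1` gives 132 nM; the step of a 3.3-fold higher number from compound 1 to compound 2 (0.52 log units; beyond the scatter) goes with 2-chlorophenyl in place of 4-fluorophenyl on an aromatic carbon. Compound 3 `O=C(c1oc(C(F)(F)F)nc1-c1ccc(F)cc1)N1CCN(c2cccc(Cl)c2)CC1` is reported in this assay as "not active" (no number reported), without a number. Compound 4 `Cc1nc(-c2ccc(F)cc2)c(C(=O)N2CCN(c3ccc(Cl)cc3)CC2)o1` has not yet been measured. It differs from compound 1 in this way: 4-chlorophenyl in place of 3-chlorophenyl on an amine nitrogen in a ring. Going by the values given here, no measured step touches the group on the amine nitrogen in the ring; the single step that has been measured, from compound 1 to compound 2, concerns the other aromatic ring, so it does not bear on this change. With no guide in either direction, only a small move is expected: the estimated step is a 1.5-fold higher number from compound 1 to compound 4 (0.18 log units; within the scatter), within or just beyond the scatter. Compound 4 is therefore expected to give about 60 nM in this assay, within a range from 15 nM to 250 nM.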

Compound 4, half-maximal inhibitory concentration: "not active" (no number reported)
For compound 4 the study gives words and no number, and the estimate cannot be compared.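

Going by these compounds alone, with no number for compound 4 in this assay, no step from compound 1 to compound 4 can be read. No measured evidence accounts for the report on compound 4. The compounds shown leave open how far 4-chlorophenyl in place of 3-chlorophenyl moves the read-out.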